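A few compounds are considered here, and "the series" means these few. Any claim that something is new, unique, unknown or untested is made for them only; others in the source may bear on it.

Compound 1 `CC(C)C(=O)OCOC(=O)N1CCN(C(=O)c2nc(Nc3cc(C4CC4)[nH]n3)c3cc(Cl)ccc3n2)C[C@H]1C` is a carbamate built on the shared core. In an assay for inhibition of serine/threonine-protein kinase PAK 4 (Homo sapiens), read by FRET and Z'-LYTE, with a stated time of 60 min, tested at 0.5 uM, in the presence of a further agent that is not named here (a higher number here means a stronger effect of the compound at the concentration tested, a lower number a weaker effect), compound 1 gives 16.4%, the highest of the three numbers recorded. Compound 3 `CC(OC(=O)C(C)C)OC(=O)N1CCN(C(=O)c2nc(Nc3cc(C4CC4)[nH]n3)c3cc(Cl)ccc3n2)C[C@H]1C` gives 9.4%, and compound 2 `C[C@@H]1CN(C(=O)c2nc(Nc3cc(C4CC4)[nH]n3)c3cc(Cl)ccc3n2)CCN1C(=O)OC(C)(C)C` gives 0.1%; the step of a number 7 percentage points lower from compound 1 to compound 3 (within the scatter) stays within the scatter, while the step of a number 16.3 percentage points lower from compound 1 to compound 2 (beyond the scatter) lies beyond it.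

Compound 4 `CC(C)OC(=O)N1CCN(C(=O)c2nc(Nc3cc(C4CC4)[nH]n3)c3cc(Cl)ccc3n2)C[C@H]1C` differs from compound 1 at the same oxygen: isopropyl in place of ((isopropylcarbonyl)oxy)methyl on an oxygen next to a carbonyl group. The nearest guide is compound 2, whose tert-butyl also sits on that oxygen and gave the drop a number 16.3 percentage points lower from compound 1 to compound 2 (beyond the scatter). An isopropyl group is expected to behave like tert-butyl here, so a step of about a number 13.4 percentage points lower from compound 1 to compound 4 (beyond the scatter) downward is expected.

Compound 4 is therefore estimated at 3%, with a range from -5% to 12%.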

Compound 4, a percentage reported as inhibition, at one concentration (the size of the read-out at that concentration, not a potency): 26.9%
Compound 4: middle estimate off by 23.9 percentage points, on the low side; the measured number lies above the stated range.
By their numbers in this assay, from the lowest: compounds 2, 3 and 1 (each within the scatter of the next, the first and the last beyond it); then compound 4.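

On an oxygen next to a carbonyl group, isopropyl gives a number 10.5 percentage points higher from compound 1 to compound 4 (beyond the scatter) and so does not share the low reading of tert-butyl. Taking one methyl off tert-butyl gives a number 26.8 percentage points higher from compound 2 to compound 4 (beyond the scatter) and replacing (isopropylcarbonyl)oxy with methyl gives a number 17.5 percentage points higher from compound 3 to compound 4 (beyond the scatter), so small edits here move the reading well beyond the scatter. The added methyl also counts differently depending on what surrounds it: the same change on two cores in this assay, a number 7 percentage points lower (within the scatter) from compound 1 to compound 3 and a number 26.8 percentage points lower (beyond the scatter) from compound 4 to compound 2, 19.8 percentage points apart, beyond the scatter of two such steps.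

From the compounds shown here alone, whether an ethyl group or a longer chain on this oxygen would read higher or lower remains open. Readings at a single concentration in this assay also give no potency for any of these compounds.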